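A few compounds are considered here, and "the series" means these few. Any claim that something is new, unique, unknown or untested is made for them only; others in the source may bear on it.

Of the compounds shown here, three have so far been tested in a functional assay on MT4 cells (Homo sapiens) for cytotoxicity, read by CellTiter-Glo, with a stated time of 5 days; on this read-out higher numbers stand for an effect only at larger amounts of compound and lower numbers for an effect already at smaller amounts. Compound 1 `Cc1ccc(-c2c(C)noc2C)cc1S(=O)(=O)NC1CCCC1` gives 1590 nM in this assay, the highest of the three numbers. Compound 2 `Cc1noc(C)c1-c1cc(S(=O)(=O)NC2CCCC2)c2cc(N3CCCC3)c(=O)[nH]c2c1` gives 140 nM, and compound 3 `Cc1ccc2ncccc2c1-c1cc(-c2c(C)noc2C)cc2nc(C3CC3)[nH]c12` gives 18 nM; each of these lies beyond the usual scatter from compound 1, so compound 1 is the one whose effect on the cells appears only at the largest amount. Among the compounds with values here, compounds 2 and 3 differ from compound 1 in many places at once, so no single-change step between measured compounds is available as a guide.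

Compound 4 `Cc1ccc(-c2cnoc2C)cc1S(=O)(=O)NC1CCCC1` has not yet been measured. It differs from compound 1 in one place: hydrogen in place of methyl on an aromatic carbon. Only one heavy atom is removed, and nothing in the measured numbers points to a direction for so small a change, so the step from compound 1 to compound 4 is expected to be small, most likely none beyond the scatter, namely a 1.1-fold higher number from compound 1 to compound 4 (0.05 log units; within the scatter). Compound 4 is therefore estimated to give about 1800 nM in this assay, within a range from 600 nM to 5500 nM.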

Compound 4, half-maximal effective concentration: 15100 nM
Compound 4: the middle estimate sits 8.4-fold (0.92 log units) below what was measured, and the stated range ends below it.
By their numbers in this assay, from the lowest: compound 3; then compound 2; then compound 1; then compound 4.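

Within this assay the removal of one methyl is not a minor edit: a 9.5-fold higher number from compound 1 to compound 4 (0.98 log units; beyond the scatter) lies beyond the scatter, so what this aromatic carbon, next to the ring nitrogen, carries clearly matters. Compounds 1, 2 and 3 all hold the 3,5-dimethyl-1,2-oxazol-4-yl group, so they could not reveal this; the change to 5-methyl-1,2-oxazol-4-yl shows that the effect on the cells then appears only at larger amounts of compound. No measurement at hand bears on why the step is this large.

As far as these compounds go, it remains open whether the same loss of this methyl would move the number as far on the different cores of compound 2 and compound 3. From the compounds shown here alone, it is also open how a longer chain such as ethyl, or an amine, would behave on this carbon.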